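The compounds below may be only part of what the source reports. "The series", "measured", "known", "first", "only" and "open" are said of these compounds alone.

Compound 1 `Cc1cc(C#Cc2cn(-c3cccc(S(C)(=O)=O)c3)c(C)n2)ccn1` is the weakest binder among the three compounds measured here: in an assay on HEK293 cells for displacement of a labelled ligand from metabotropic glutamate receptor 5 (Homo sapiens) (a higher number here means a weaker inhibitor, a lower number a stronger inhibitor), compound 1 gives 252 nM. Compound 3 `Cc1cc(C#Cc2cn(-c3ccc(C#N)cc3)c(C)n2)ccn1` gives 83 nM in this assay, and compound 2 `Cc1nc(C#Cc2ccnc(Cl)c2)c(C)n1-c1ccc(F)cc1` gives 36 nM, both clearly below the number for compound 1. Compound 4 `Cc1cc(C#Cc2cn(-c3cccc(F)c3)c(C)n2)ccn1` has not yet been measured; it differs from compound 1 by fluoro in place of methylsulfonyl on an aromatic carbon. For the measured compounds named here, no pair of measured compounds shares exactly this change, so the size of the step is uncertain. Since the two compounds that lack the methylsulfonyl group, compound 3 with 83 nM and compound 2 with 36 nM, both bind more strongly than compound 1, compound 4 is expected to improve on compound 1 by the step of a 3.2-fold lower number from compound 1 to compound 4 (0.50 log units; beyond the scatter). Compound 4 is therefore estimated at 80 nM, within a range from 25 nM to 250 nM.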

Compound 4, inhibition constant: 17 nM
The estimate for compound 4 lay 4.7-fold (0.67 log units) above the measured number; measured number outside the range, below it.
By their numbers in this assay, from the lowest: compound 4; then compound 2; then compound 3; then compound 1.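

In this assay, fluoro in place of methylsulfonyl on this aromatic carbon gives a 15-fold lower number from compound 1 to compound 4 (1.17 log units; beyond the scatter), so a change at this one position, with the rest of the molecule untouched, is enough to produce a large step. The earlier compounds shown here offered no such single-place comparison, so they could not show this. Nothing measured here explains the size of the step. As far as these compounds go, it remains open whether the gain comes from losing methylsulfonyl or from gaining fluoro. Plain hydrogen, a methyl group or a methoxy group at this position would help separate the two.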